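Methyl to Trifluoromethyl: What to Expect of Compound 4

The compounds below may be only part of what the source reports. "The series", "measured", "known", "first", "only" and "open" are said of these compounds alone.

In a functional assay for antagonist activity at transient receptor potential cation channel subfamily V member 1 (Homo sapiens), read by FLIPR and calcium flux (a higher number here means a weaker inhibitor, a lower number a stronger inhibitor), compound 2 `Cc1ccccc1N1CCC(C(=O)Nc2ccc3c(c2)NC(=O)CO3)CC1` gives 150 nM, the lowest of the two numbers recorded so far. Compound 3 `CC(=O)N1CCc2ccc(NC(=O)C3CCN(c4cccc(C(F)(F)F)c4)CC3)cc21` gives 800 nM, a gap beyond the usual scatter. Compound 1 `CC(=O)N1CCc2cc(NC(=O)C3CCN(c4cccc(C(F)(F)F)c4)CC3)ccc21` reaches only a limit of the assay, > 9000 nM, as noted in the limit of > 9000 nM in this assay, at which 1 of the 3 values shown sits. Compound 4 `O=C1COc2ccc(NC(=O)C3CCN(c4ccccc4C(F)(F)F)CC3)cc2N1` differs from compound 2 by a single change: trifluoromethyl in place of methyl on an aromatic carbon. Compounds 1 and 3 also carry a trifluoromethyl group, but on a different core, so their numbers do not speak directly to this change. Among the compounds with values here, with no measured step of this kind available, the expected step from compound 2 to compound 4 is a 1.4-fold lower number from compound 2 to compound 4 (0.13 log units; within the scatter), small and within the scatter. Compound 4 is therefore estimated at 110 nM, between 30 nM and 500 nM.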

Compound 4, half-maximal inhibitory concentration: 380 nM
Beside the measured number, compound 4's estimate is 3.5-fold (0.54 log units) below it; the range from low to high includes it.
By their numbers in this assay, from the lowest: compound 2; then compound 4; then compound 3. At a limit, above all of these: compound 1.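

In this assay, trifluoromethyl in place of methyl gives a 2.5-fold higher number from compound 2 to compound 4 (0.40 log units; beyond the scatter), so the change weakens inhibition modestly at this place, ortho to a large group. Within the data shown here, this is the first measured step for the change on a single core, and there methyl is the better of the two groups. Nothing measured here accounts for the loss.

On these data alone, whether a chlorine atom, a methoxy group or a nitrile at this place would match methyl remains open. So does whether the same change would have a similar effect on another core.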